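Aryl swap on the ring nitrogen of compound 2

The compounds below may be only part of what the source reports. "The series", "measured", "known", "first", "only" and "open" are said of these compounds alone.

Compound 2 `O=C(N/N=c1\scc(-c2ccc(Cl)cc2)n1-c1ccc(Cl)cc1Cl)c1ccc(O)cc1` is one of three compounds with numbers in a functional assay on HOP-92 cells (Homo sapiens) for cytotoxicity, read by sulforhodamine B assay, with a stated time of 48 h; a higher number here means a weaker inhibitor of growth, a lower number a stronger inhibitor of growth. Compound 2 gives 2950 nM, the second highest of the three. Compound 1 `COc1ccc(-c2cs/c(=N\NC(=O)c3ccc(O)cc3)n2-c2ccc(OC)cc2OC)cc1` gives 3310 nM, a number within the scatter of that of compound 2, so no order between these two is claimed. Compound 3 `O=C(c1ccc(O)cc1)n1nc(-c2c(Cl)cccc2Cl)sc1=S`, built on a different core, gives 324 nM, a number beyond the scatter below that of compound 2. Among the measured compounds shown here, no pair among the three differs in one place, so no single measured step is available.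

Compound 4 `COc1ccc(-n2c(-c3ccc(Cl)cc3)cs/c2=N\NC(=O)c2ccc(O)cc2)c(OC)c1` differs from compound 2 in one place: 2,4-dimethoxyphenyl in place of 2,4-dichlorophenyl on an aromatic nitrogen. The group sits on an aromatic nitrogen of a five-membered aromatic ring with 1 nitrogen and 1 sulfur, next to the ring atom that bears a 4-chlorophenyl group, two ring bonds from the ring sulfur.

Compound 1 also carries a 2,4-dimethoxyphenyl group on that aromatic nitrogen, and its number matches that of compound 2 within the scatter, although compound 1 differs elsewhere as well. The step from compound 2 to compound 4 is therefore expected to be small, a 1.0-fold higher number from compound 2 to compound 4 (0.01 log units; within the scatter), with no direction beyond the scatter. Compound 4 is expected to give 3000 nM, in the range 1200 nM to 8000 nM.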

Compound 4, concentration for 50% growth inhibition: 14500 nM
For compound 4 the middle estimate is 4.8-fold (0.68 log units) below the measured one; the measured number lies above the stated range.
By their numbers in this assay, from the lowest: compound 3; then compounds 2 and 1 (each within the scatter of the next); then compound 4.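

In this assay, the group on the aromatic nitrogen is not a silent position: 2,4-dimethoxyphenyl in place of 2,4-dichlorophenyl, with the 4-chlorophenyl group kept, gives a 4.9-fold higher number from compound 2 to compound 4 (0.69 log units; beyond the scatter). Chloro in place of methoxy on an aromatic carbon, with the 2,4-dimethoxyphenyl group kept, gives a 4.4-fold higher number from compound 1 to compound 4 (0.64 log units; beyond the scatter), so the agreement within the scatter between compound 1 and compound 2 conceals two single changes that run in opposite directions along the path through compound 4. Nothing available explains either step, and no measurement bears on the cause of the difference between the two aryl groups.

Open, on these data alone, is how the two changes combine, since that can be read only from a compound that pairs 2,4-dichlorophenyl on the aromatic nitrogen with methoxy in place of chloro on the aromatic carbon. Also open, as far as these compounds go, is whether the step at the nitrogen belongs to the methoxy groups or the loss of the chlorines, which a 2,4-dimethylphenyl or an unsubstituted phenyl group at that position would help to separate.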